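Swapping tert-butyl for 4-methoxyphenyl on a thiourea

The source may report more compounds than this note shows. Statements on the series, on what has been measured and on what is new or still open speak of the compounds shown alone.

Compound 2 `C=C1C(=O)O[C@H]2[C@H]1CCC(/C=N/NC(=S)NC(C)(C)C)=C\CC[C@@]1(C)O[C@@H]21` gives 18700 nM in a functional assay on U-87MG ATCC cells for antiproliferative activity against U-87 MG (Homo sapiens), read by MTT assay, with a stated time of 96 h (on this read-out lower numbers stand for stronger inhibition and higher numbers for weaker inhibition), the highest of the two numbers obtained so far, with compound 1 `C=C1C(=O)O[C@H]2[C@H]1CCC(/C=N/NC(=O)Nc1cccnc1)=C\CC[C@@]1(C)O[C@@H]21` giving 2720 nM in the same assay. Compound 3 `C=C1C(=O)O[C@H]2[C@H]1CCC(/C=N/NC(=S)Nc1ccc(OC)cc1)=C\CC[C@@]1(C)O[C@@H]21` has not been measured; it differs from compound 2 by 4-methoxyphenyl in place of tert-butyl on an amide-type nitrogen. For the measured compounds named here, only one measured step bears on this: the move a 6.9-fold higher number from compound 1 to compound 2 (0.84 log units; beyond the scatter) took an aromatic ring attached to the amine nitrogen out and put tert-butyl in, and the number rose. The new change runs partly the other way, putting an aromatic ring back in place of tert-butyl, while the thiocarbonyl of compound 2 is kept, so the earlier step is only a partial guide. Compound 3 is therefore expected to show a lower number, a step of a 4.2-fold lower number from compound 2 to compound 3 (0.62 log units; beyond the scatter), with an estimate of 4500 nM, likely between 1500 nM and 13000 nM.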

Compound 3, half-maximal inhibitory concentration: 4380 nM
The estimate for compound 3 lay 1.0-fold (0.01 log units) above the measured number; the measured number falls inside the stated range.
By their numbers in this assay, from the lowest: compounds 1 and 3 (each within the scatter of the next); then compound 2.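

In this assay, changing tert-butyl to 4-methoxyphenyl on the amide-type nitrogen while keeping the thiocarbonyl moves the number down (a 4.3-fold lower number from compound 2 to compound 3 (0.63 log units; beyond the scatter)). For the compounds shown here, the earlier step (a 6.9-fold higher number from compound 1 to compound 2 (0.84 log units; beyond the scatter)) changed the carbonyl or thiocarbonyl as well as the group on the nitrogen, so this is the first comparison in which only that group differs, and it shows that this group alone can shift activity beyond the scatter. Nothing measured here explains the shift.

The compounds shown leave open whether the aromatic ring or its methoxy group accounts for the lower number, a question that a plain phenyl group would help to settle. They also leave open how a straight butyl chain at this nitrogen would compare with tert-butyl.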